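The compounds below may be only part of what the source reports. "The series", "measured", "known", "first", "only" and "open" are said of these compounds alone.

Compound 1 `CNC(=O)CCCCCCCn1nc(-c2ccc3oc(N)nc3c2)c2c(N)ncnc21` carries a 5-(methylcarbamoyl)pentyl chain on the shared core, and in a functional assay on MDA-MB-231 cells (Homo sapiens) for inhibition, read by MTT assay, with a stated time of 72 h (on this read-out higher numbers stand for weaker inhibition and lower numbers for stronger inhibition), compound 1 gives 2900 nM, the lowest of the two numbers shown. The nearest number is that of compound 2 `Nc1ncnc2c1c(-c1cnc3[nH]ccc3c1)nn2CCCCCCCCCC(=O)NO`, which in this assay gives 10100 nM. Compound 3 `Nc1ncnc2c1c(-c1cnc3[nH]ccc3c1)nn2CCCCCC(=O)NO` gives only a limit in this assay, > 100000 nM; that is the limit of > 100000 nM in this assay, at which 1 of the 3 values shown sits.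

Compound 4 `Nc1nc2cc(-c3nn(CCC(=O)NO)c4ncnc(N)c34)ccc2o1` differs from compound 1 by hydroxycarbamoyl in place of 5-(methylcarbamoyl)pentyl on a saturated chain carbon, two bonds along the chain from an aromatic nitrogen. Within the data shown here, the one measured step that bears on this is an at least 9.9-fold higher number from compound 2 to compound 3 (0.99 log units; beyond the scatter), where shortening a hydroxycarbamoyl-bearing chain brought a much higher number. Compound 4 carries an even shorter hydroxycarbamoyl chain than compound 3, so a step toward weaker inhibition, of similar or greater size, is expected, namely a 17-fold higher number from compound 1 to compound 4 (1.24 log units; beyond the scatter). Compound 4 is therefore estimated at 50000 nM, within a range from 8000 nM to 150000 nM, with a real chance that this assay reports only a limit.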

Compound 4, half-maximal inhibitory concentration: > 50000 nM
Compound 4: only a limit was reported (the forecaster's own chance of this, stated with the estimate: 40%); the middle value lies on the limit itself.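

In this assay compound 4 gives only a limit: the limit of > 50000 nM in this assay, at which 1 of the 4 values shown sits. Exchanging 5-(methylcarbamoyl)pentyl for hydroxycarbamoyl, on a saturated chain carbon, two bonds along the chain from an aromatic nitrogen, brings an at least 17-fold higher number from compound 1 to compound 4 (1.23 log units; beyond the scatter). The earlier step stayed among compounds that all end in hydroxycarbamoyl and share a different group on the core, whereas this one shows that on the core of compound 1 a short chain ending in hydroxycarbamoyl also goes with a much higher number than the longer chain ending in methylcarbamoyl.

This step changes chain length and end group at once, so the compounds shown leave open which of the two accounts for it. A longer chain ending in hydroxycarbamoyl on the core of compound 1, or a methylcarbamoyl or carboxylic acid on the short chain, would separate the two.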